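Thiophen-2-yl in place of 4-cyanophenyl on the shared core

The source may hold more compounds than are shown below. What is called first, only, known or untested is meant among the compounds shown, and "the series" means these compounds.

In a functional assay on HeLa cells (Homo sapiens) for inhibition, read by MTT assay, with a stated time of 48 h (a lower number here means a stronger inhibitor, a higher number a weaker inhibitor), compound 1 `COc1ccc(-c2nc3ccccn3c2Sc2ccccc2)cc1` reaches only a limit, > 100000 nM. Among the measured compounds shown here, compound 2 `N#Cc1ccc(-c2nc3ccccn3c2Sc2ccccc2)cc1` gives 64200 nM, the only actual number so far, so its standing rests on a single comparison. The next compound is compound 3 `c1ccc(Sc2c(-c3cccs3)nc3ccccn23)cc1`, which carries thiophen-2-yl in place of 4-cyanophenyl on an aromatic carbon. For the measured compounds named here, one measured step bears on this change: an at least 1.5-fold lower number from compound 1 to compound 2 (0.19 log units; that floor lies within the scatter). As far as these compounds go, that step is anchored on (the limit of > 100000 nM in this assay, at which 1 of the 2 values shown sits), so its true size is unknown. It gives no firm basis for predicting a thiophen-2-yl group, and no clear direction follows for this assay. The expected change is small, with no shift beyond the scatter: a 1.1-fold higher number from compound 2 to compound 3 (0.04 log units; within the scatter). For compound 3 the estimated value is 70000 nM, with an expected range of 30000 nM to 100000 nM.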

Compound 3, half-maximal inhibitory concentration: 19900 nM
Beside the measured number, compound 3's estimate is 3.5-fold (0.55 log units) above it; the measured number lies below the stated range.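

In this assay, among the compounds shown here, this position on the five-membered aromatic ring with 2 nitrogen tolerates more than a para-substituted phenyl swap could show: thiophen-2-yl in place of 4-cyanophenyl gives a 3.2-fold lower number from compound 2 to compound 3 (0.51 log units; beyond the scatter), the only step with real numbers at both ends and a size beyond the scatter. Against 4-methoxyphenyl, thiophen-2-yl gives an at least 5.0-fold lower number from compound 1 to compound 3 (0.70 log units; beyond the scatter), which makes compound 3 the most potent of the three shown. That size is only a floor: the limit of > 100000 nM in this assay, at which 1 of the 3 values shown sits.

The change swaps a six-membered carbon ring for a five-membered ring with sulfur and also removes the substituent, so the data cannot say which of these matters. Plain phenyl, furan-2-yl or pyridin-3-yl at this position would separate those contributions, and an amine on the thiophene would test whether the ring accepts substitution.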